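A few compounds are considered here, and "the series" means these few. Any claim that something is new, unique, unknown or untested is made for them only; others in the source may bear on it.

Measured compounds:
- compound 1, `CN(C(=O)NC(=O)c1c(F)cccc1F)c1nc(C(F)(F)F)c(C(=O)N/N=C/c2cccc(C(F)(F)F)c2)s1`; in a functional assay on HeLa cells (Homo sapiens) for inhibition, read by MTT assay, with a stated time of 72 h (a higher number here means a weaker inhibitor, a lower number a stronger inhibitor), compound 1 gives 21.6 ug/mL.
- compound 2, `CN(C(=O)NC(=O)c1ccc([N+](=O)[O-])cc1)c1nc(C(F)(F)F)c(C(=O)N/N=C/c2ccc([N+](=O)[O-])cc2)s1`; compound 2 gives 8.42 ug/mL.
- compound 3, `Cc1nc(N(C)C(=O)NC(=O)c2c(F)cccc2F)sc1C(=O)N/N=C/c1cccc(C(F)(F)F)c1`; compound 3 gives 26.8 ug/mL.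

Among these three numbers compound 1 stands second highest. Its nearest neighbour is compound 3, reached by a 1.2-fold higher number from compound 1 to compound 3 (0.09 log units; within the scatter), a change of methyl for trifluoromethyl on the shared core. Within the data shown here, compound 2, which differs from compound 1 in two places at once, shows a lower number, beyond the scatter; no single step connects the two.

Compound 4, `CN(C(=O)NC(=O)c1ccc(F)c(F)c1)c1nc(C(F)(F)F)c(C(=O)N/N=C/c2cccc(C(F)(F)F)c2)s1`, has not yet been measured. It differs from compound 1 by 3,4-difluorophenyl in place of 2,6-difluorophenyl on a carbonyl carbon. Among the measured compounds shown here, no measured step moves the difluorophenyl group on the carbonyl carbon, so nothing bears on this change directly; the one step that is known, from compound 1 to compound 3, stayed within the scatter. Compound 4 is therefore expected to sit close to compound 1, with a 1.1-fold lower number from compound 1 to compound 4 (0.03 log units; within the scatter), and its value in this assay is estimated at 20 ug/mL, between 8 ug/mL and 50 ug/mL.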

Compound 4, half-maximal inhibitory concentration: 4.21 ug/mL
The estimate for compound 4 lay 4.8-fold (0.68 log units) above the measured number; measured number below the stated range.
By their numbers in this assay, from the lowest: compounds 4 and 2 (each within the scatter of the next); then compounds 1 and 3 (each within the scatter of the next).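

In this assay, among these compounds, the step with 3,4-difluorophenyl in place of 2,6-difluorophenyl on a carbonyl carbon gives a 5.1-fold lower number from compound 1 to compound 4 (0.71 log units; beyond the scatter) and is the first measured change at this position. The two groups have the same atoms and differ only in how they are joined, so the arrangement of the two fluorines alone is enough to move the number beyond the scatter, whereas the step of methyl for trifluoromethyl on the shared core gave a 1.2-fold higher number from compound 1 to compound 3 (0.09 log units; within the scatter) and did not. Nothing shown here accounts for this difference between the two arrangements.

The compounds shown cannot tell whether the lower number comes from losing the 2,6-difluorophenyl group or from gaining the 3,4-difluorophenyl group, and unsubstituted phenyl, 3-fluorophenyl or 4-fluorophenyl at this position would bear on that. On these data alone, it also remains open whether the same step holds on the core that carries methyl in place of trifluoromethyl.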